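Swapping the 2-carboxy-1H-indol-5-yl group: working notes

This account rests on a few compounds, and the source may have more. Where it says the series, first, only, none or still open, it means among the compounds named here.

- Compound 1 `Cn1c(=O)c(S(=O)(=O)c2ccc(F)cc2F)cc2cnc(Nc3ccc4[nH]c(C(=O)O)cc4c3)nc21`: 10000 nM
- Compound 2 `COC(=O)Cn1c(=O)c(S(=O)(=O)c2ccc(F)cc2F)cc2cnc(Nc3ccc4[nH]ccc4c3)nc21`: 5000 nM
- Compound 3 `Cn1c(=O)c(S(=O)(=O)Cc2ccc(F)cc2F)cc2cnc(Nc3ccc4[nH]ccc4c3)nc21`: 1000 nM

All three values come from a functional assay on K562 cells (Homo sapiens) for inhibition, read by trypan blue exclusion, with a stated time of 72 h; on this read-out lower numbers stand for stronger inhibition and higher numbers for weaker inhibition. Compound 1 at 10000 nM lies within the scatter of compound 2. Compound 3 lies beyond the scatter on the lower side of compound 1, so compound 1 does not mark the best that this small set reaches.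

The next compound to consider is compound 4 `Cn1c(=O)c(S(=O)(=O)c2ccc(F)cc2F)cc2cnc(Nc3ccc4c(c3)CC(=O)N4)nc21`. It keeps the core of compound 1 and loses the 2-carboxy-1H-indol-5-yl group, with a new group taking its place on a nitrogen on an aromatic ring: a group of 10 heavy atoms (8 carbon, 1 nitrogen, 1 oxygen; one five-membered non-aromatic ring with 1 hetero atom, one six-membered aromatic ring of carbon only) in place of a group of 12 heavy atoms (9 carbon, 1 nitrogen, 2 oxygen; one five-membered aromatic ring with 1 hetero atom, one six-membered aromatic ring of carbon only), on a nitrogen on an aromatic ring.

Going by the values given here, no two measured compounds differ in one place only, so the data contain no direct measure of this change. The expectation therefore rests on a single observation: compound 3, at 1000 nM, shows that numbers well under that of compound 1 are possible in this set. The expected move in this assay is towards stronger inhibition, beyond the scatter, though this is held with little confidence. The estimated step is a 6.7-fold lower number from compound 1 to compound 4 (0.82 log units; beyond the scatter). Compound 4 is expected at 1500 nM, with an estimated range of 300 nM to 7000 nM.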

Compound 4, half-maximal inhibitory concentration: 15000 nM
Compound 4: the middle estimate sits 10-fold (1.00 log units) below what was measured; the measured number lies above the stated range.
By their numbers in this assay, from the lowest: compound 3; then compounds 2, 1 and 4 (each within the scatter of the next, the first and the last beyond it).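

In this assay, the one-place exchange of the 2-carboxy-1H-indol-5-yl group for the group with the five-membered non-aromatic ring, on a nitrogen on an aromatic ring, gives a 1.5-fold higher number from compound 1 to compound 4 (0.18 log units; within the scatter), so this read-out does not tell the two compounds apart. Going by these compounds alone, this is the first direct reading at this place: with the rest of compound 1 held fixed, removing the carboxy group and the five-membered aromatic ring together opens no difference beyond the scatter. No measurement is available that would explain this result.

Still open, going by these compounds, is whether another group on this nitrogen, such as a phenyl ring carrying an aminoalkyl chain, a morpholine or a longer chain ending in a carboxylic acid, can move the number beyond the scatter. Also open, on these data alone, is whether this same exchange reads alike in a compound with a different group elsewhere on the shared core, as one pair in one assay cannot show this.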